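Permeability working notes: compound 4 against compound 1

The source may report more compounds than this note shows. Statements on the series, on what has been measured and on what is new or still open speak of the compounds shown alone.

Compound 1 `COc1ccc(F)cc1CNCCCNc1ccnc2cc(Oc3ccc(C(C)(C)C)cc3)ccc12` gives 317 10^-6 cm/s in an ADME assay for permeability, using PAMPA, with a stated time of 30 min, at pH 7.4; a lower number here means that the compound crosses the layer more slowly, a higher number that the compound crosses the layer faster. Compound 2 `CC(C)(C)c1ccc(Oc2ccc3c(NCCCNCc4ccco4)ccnc3c2)cc1` gives 317 10^-6 cm/s in this assay, and compound 3 `COc1cccc(CNCCCNc2ccnc3cc(Oc4ccc(C(C)(C)C)cc4)ccc23)c1O` gives 317 10^-6 cm/s in this assay, so compound 1 stands level with both at the digits shown. The three known steps, no change at the digits printed from compound 1 to compound 2 (within the scatter), no change at the digits printed from compound 1 to compound 3 (within the scatter) and no change at the digits printed from compound 2 to compound 3 (within the scatter), all exchange the aryl group on a saturated chain carbon bound to an amine nitrogen, and all stay within the scatter.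

Compound 4 `COc1ccc(F)cc1CNCCCNc1ccnc2cc(Cc3cccc(C(F)(F)F)c3)ccc12` is not yet measured. The change from compound 1 to compound 4 is 3-(trifluoromethyl)benzyl in place of 4-(tert-butyl)phenoxy on an aromatic carbon. Among the measured compounds shown here, no measured step touches this aromatic carbon, so the known steps bear on compound 4 only in showing that the read-out sat at one level across three neighbours differing elsewhere. For the measured compounds named here, with the net charge unchanged and no step moving beyond the scatter, the step from compound 1 to compound 4 is expected to be no change at the digits printed from compound 1 to compound 4 (within the scatter), that is, nothing beyond the scatter. Compound 4 is estimated at 317 10^-6 cm/s in this assay, expected to fall between 180 10^-6 cm/s and 550 10^-6 cm/s.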

Compound 4, apparent permeability: 23 10^-6 cm/s
Estimate against measurement, compound 4: 14-fold (1.14 log units) above, and the stated range ends above it.
By their numbers in this assay, from the lowest: compound 4; then compounds 1, 2 and 3 (each within the scatter of the next).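

In this assay, the exchange on this aromatic carbon gives a 14-fold lower number from compound 1 to compound 4 (1.14 log units; beyond the scatter), so this position can move the read-out, whereas the three steps at the aryl group on the chain all stayed within the scatter. The leaving 4-(tert-butyl)phenoxy and the entering 3-(trifluoromethyl)benzyl match in heavy-atom count, aromatic ring and net charge, but the first holds oxygen and a hydrogen-bond acceptor, while the second holds fluorine and no acceptor. No measurement at hand explains the size of this step.

The exchange alters the linking atom, the ring substituent and its ring position together, and the compounds shown cannot assign the step to any one of these. As far as these compounds go, both 4-(tert-butyl)benzyl and 3-(trifluoromethyl)phenoxy on this carbon would separate these contributions, and the response to an amine there remains open.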